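Carbamate Variation at a Glucose-dependent Insulinotropic Receptor

This account rests on a few compounds, and the source may have more. Where it says the series, first, only, none or still open, it means among the compounds named here.

compound 1 `CC(C)OC(=O)N1CCC(O[C@H]2CC[C@H](Oc3cnc(S(C)(=O)=O)cn3)CC2)CC1` 120%
compound 2 `CC1(OC(=O)N2CCC(O[C@H]3CC[C@H](Oc4cnc(S(C)(=O)=O)cn4)CC3)CC2)CC1` 123%

In a functional assay on isolated protein for agonist activity at Glucose-dependent insulinotropic receptor (Rattus norvegicus), read by HTRF and cAMP accumulation (on this read-out lower numbers stand for smaller maximal responses and higher numbers for larger maximal responses), compound 2 stands together with compound 1, since the step of a number 3 percentage points higher from compound 1 to compound 2 (within the scatter) lies within the scatter. Compound 3 `C[C@H](CF)OC(=O)N1CCC(O[C@H]2CC[C@H](Oc3cnc(S(C)(=O)=O)cn3)CC2)CC1` differs from compound 2 in one place: 1-(fluoromethyl)ethyl in place of 1-methylcyclopropyl on an oxygen next to a carbonyl group. Within the data shown here, the only measured step that bears on this change is the one on the same oxygen, a number 3 percentage points higher from compound 1 to compound 2 (within the scatter), which stayed within the scatter. Accordingly no step beyond the scatter is expected in this assay a number 3 percentage points lower from compound 2 to compound 3 (within the scatter). Compound 3 is therefore estimated at 120%, with a range from 105% to 135%.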

Compound 3, largest response reached (Emax), in percent of the reference or control that the assay uses: 115%
Compound 3: the middle estimate sits 5 percentage points above what was measured, within the range that was stated.
By their numbers in this assay, from the lowest: compounds 3, 1 and 2 (each within the scatter of the next).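

In this assay, the exchange of 1-methylcyclopropyl for 1-(fluoromethyl)ethyl on an oxygen next to a carbonyl group comes out as a number 8 percentage points lower from compound 2 to compound 3 (within the scatter) and so shows no change beyond the scatter. Fluoro in place of hydrogen on the saturated chain carbon gives a number 5 percentage points lower from compound 1 to compound 3 (within the scatter) and also stays within the scatter, so this position accepts a fluorinated open chain as well as the earlier groups. Nothing available accounts for these steps. Still open, on these data alone, is whether a longer chain or an amine on this oxygen would stay within the scatter, and how the opposite stereocentre of 1-(fluoromethyl)ethyl would read.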